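Swapping Amino for Hydrogen on the Shared Core

The compounds below may be only part of what the source reports. "The series", "measured", "known", "first", "only" and "open" are said of these compounds alone.

Compound 1 `CCCCC(CCO)n1cnc2cncnc21`: > 50000 nM (a limit)
Compound 2 `CCCCCCC(CCO)n1cnc2c(Cl)ncnc21`: 11900 nM
Compound 3 `CCCCCCC(CCO)n1cnc2c(N)ncnc21`: > 50000 nM (a limit)

These values come from a functional assay on HCT-116 cells (Homo sapiens) for antiproliferative activity, read by MTT assay, with a stated time of 48 h; a higher number here means a weaker inhibitor, a lower number a stronger inhibitor. Compound 3 gives only a limit, > 50000 nM. That is the limit of > 50000 nM in this assay, at which 2 of the 3 values shown sit. The change to compound 4 `CCCCCCC(CCO)n1cnc2cncnc21` is hydrogen in place of amino on an aromatic carbon. Within the data shown here, the one measured step at this place is an at least 4.2-fold higher number from compound 2 to compound 3 (0.62 log units; beyond the scatter), with amino in place of chloro, and it is at least modest. Compound 1, also bearing hydrogen there, gives only a limit, > 50000 nM. A small step toward a lower number is therefore expected, an at least 1.2-fold lower number from compound 3 to compound 4 (0.09 log units; that floor lies within the scatter), possibly none beyond the scatter. Compound 4 is estimated at 40000 nM, within an expected range of 15000 nM to 90000 nM.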

Compound 4, half-maximal inhibitory concentration: > 50000 nM
Compound 4 gave a limit, no number; the forecaster's own chance of this, stated with the estimate: 55%; middle value at least 1.2-fold (0.09 log units) from the limit.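

Hydrogen in place of chloro on this aromatic carbon gives an at least 4.2-fold higher number from compound 2 to compound 4 (0.62 log units; beyond the scatter), so the loss seen with amino also appears with hydrogen, and compound 2 alone keeps a measured number. In this assay compound 4 gives > 50000 nM, which is a limit. The steps to compound 3 and to compound 1 cannot be read, so hydrogen, amino and the change in chain length stay unranked, and the values gather at one limit: the limit of > 50000 nM in this assay, at which 3 of the 4 values shown sit.

As far as these compounds go, whether a fluoro, bromo or methoxy group on this aromatic carbon would also give a measured number stays open. So does how compound 2 would respond to a shorter or longer chain.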